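The compounds below may be only part of what the source reports. "The series", "measured", "known", "first", "only" and "open" are said of these compounds alone.

Measured compounds:
compound 1 `O=[N+]([O-])c1c(CS(=O)(=O)c2ccccc2)nc2c(C#Cc3ccc(F)cc3)cc(Cl)cn12`, an ADME assay on HepG2 cells (Homo sapiens) for cytotoxicity, read by MTT assay, with a stated time of 72 h; a higher number here means that more compound is tolerated, a lower number that less compound is tolerated: > 3900 nM
compound 2 `O=[N+]([O-])c1c(CS(=O)(=O)c2ccccc2)nc2c(C#Cc3ccccc3F)cc(Cl)cn12`, this assay: > 3900 nM
compound 3 `O=[N+]([O-])c1c(CS(=O)(=O)c2ccccc2)nc2c(C#CCOc3ccccc3)cc(Cl)cn12`, this assay: 8400 nM

The value of compound 1 is a limit of this assay, not a number. The value of compound 2 is likewise a limit. Within the data shown here, compound 3 therefore stands as the only real number in the set; the other two results are limits (the limit of > 3900 nM in this assay, at which 2 of the 3 values shown sit), so no step among the three measured compounds can be read: a step that the two limits leave unreadable from compound 1 to compound 2, a step that the limit leaves unreadable from compound 1 to compound 3 and a step that the limit leaves unreadable from compound 2 to compound 3 all remain of unreadable size.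

Compound 4 `O=[N+]([O-])c1c(CS(=O)(=O)c2ccccc2)nc2c(C#CC3(O)CCCC3)cc(Cl)cn12` is not yet measured. It differs from compound 3 in one place: 1-hydroxycyclopentyl in place of phenoxymethyl on a triple-bonded carbon.

Among the measured compounds shown here, no measured step bears on this change; the readable information is only the single number of compound 3 and the two limits. The expectation for compound 4 therefore rests on compound 3 alone, with the step of a 1.1-fold higher number from compound 3 to compound 4 (0.03 log units; within the scatter) expected to stay within the usual scatter, in no preferred direction. Compound 4 is estimated at 9000 nM in this assay, with a range from 3500 nM to 25000 nM, and a fair chance that only a limit is reported.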

Compound 4, half-maximal cytotoxic concentration: > 31300 nM
Compound 4 gave a limit, no number (the forecaster's own chance of this, stated with the estimate: 40%); at least 3.4-fold (0.54 log units) between middle value and limit.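

In this assay, the change from phenoxymethyl to 1-hydroxycyclopentyl on a triple-bonded carbon gives the only readable step among these compounds: an at least 3.7-fold higher number from compound 3 to compound 4 (0.57 log units; beyond the scatter). The position therefore accepts the loss of the six-membered aromatic ring of carbon only and the entry of a five-membered non-aromatic ring carrying a hydrogen-bond donor, with more compound tolerated rather than less. The result for compound 4 is a limit and not a number, so the step has a lower bound but no measured size: the limit of > 31300 nM in this assay, at which 1 of the 4 values shown sits.

As far as these compounds go, the steps from compound 1 and compound 2 to compound 4 cannot be read, and the results for compound 1 and compound 2 are also limits: the limit of > 3900 nM in this assay, at which 2 of the 4 values shown sit. Whether the step follows the hydroxyl or the change of ring stays open, as a plain cyclopentyl would be needed to separate the two, and what an amine, a carboxylic acid or a longer chain on the same triple-bonded carbon would give in this assay is also open.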